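Series notes: from the benzoyl analog to the acetamido analog

The source may hold more compounds than are shown below. What is called first, only, known or untested is meant among the compounds shown, and "the series" means these compounds.

The shared core is seen in compound 1 `COc1ccc(NC(=S)Nc2ccc3[nH]ccc3c2)cc1` and compound 2 `O=C(c1ccccc1)c1ccc(NC(=S)Nc2ccc3[nH]ccc3c2)cc1`. In an ADME assay on cells for inhibition of Amine oxidase [flavin-containing] A (Homo sapiens), read by spectrophotometry (a lower number here means a stronger inhibitor, a higher number a weaker inhibitor), compound 1 gives 36000 nM, a weak reading. In this assay compound 2 gives "not active" (no number reported); no number stands against it, so it cannot be placed on the scale beside compound 1, and nothing about the size of the gap between the two can be said beyond that one has a figure and the other has none.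

Compound 3 `CC(=O)Nc1ccc(NC(=S)Nc2ccc3[nH]ccc3c2)cc1` follows from compound 2 by acetamido in place of benzoyl on an aromatic carbon. Within the data shown here, no measured pair shows this change, so the size of the step from compound 2 to compound 3 cannot be drawn from the data; with compound 2 reported only as inactive, a step cannot be computed at all. The expectation is that compound 3 stays in the weak range where compound 1 sits, with a real chance that it, too, returns no number in this assay. Compound 3 is expected to give 40000 nM in this assay, within an estimated range of 10000 nM to 150000 nM.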

Compound 3, half-maximal inhibitory concentration: 71000 nM
Beside the measured number, compound 3's estimate is 1.8-fold (0.25 log units) below it, within the range that was stated.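

At the aromatic carbon para to a large group, acetamido in place of methoxy gives in this assay a 2.0-fold higher number from compound 1 to compound 3 (0.29 log units; within the scatter) and so these two groups are not told apart at this position by this read-out. Compound 3 also shows that a group with no ring and with a hydrogen-bond donor, which benzoyl does not have, gives a figure at this carbon, 71000 nM in this series, while compound 2 has none; the step between those two cannot be read, so the benzoyl-to-acetamido change can be recorded only as a number standing where none stood. No measurement is available that bears on the reason for either result.

Open, going by these compounds, is whether an amine or a carboxylic acid at this carbon would give a reading clearly apart from those of compound 1 and compound 3. Also open, on these data alone, is whether a longer chain on the acetamido carbonyl, or a benzamide that restores the six-membered aromatic ring while keeping the amide hydrogen, would keep a measurable number.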